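Replacing 1-benzothiophen-2-yl with 5-methylthiophen-2-yl in compound 3

This account rests on a few compounds, and the source may have more. Where it says the series, first, only, none or still open, it means among the compounds named here.

In a functional assay on Jurkat cells (Homo sapiens) for inhibition (a higher number here means a weaker inhibitor, a lower number a stronger inhibitor), compound 3 `CCOC(=O)c1cnc(N(C)N2C(=O)C=C(C)C2=O)nc1-c1cc2ccccc2s1` gives 130 nM as the lowest of three numbers, with compound 1 `CCOC(=O)c1cnc(NN2C(=O)C=C(C)C2=O)nc1-c1cc2ccccc2s1` at 800 nM and compound 2 `CCc1nc(NN2C(=O)C=C(C)C2=O)ncc1C#N` at 1100 nM for comparison.

Compound 4 `CCOC(=O)c1cnc(N(C)N2C(=O)C=C(C)C2=O)nc1-c1ccc(C)s1` carries 5-methylthiophen-2-yl in place of 1-benzothiophen-2-yl on an aromatic carbon ortho to an ethoxycarbonyl group 5-methylthiophen-2-yl in place of 1-benzothiophen-2-yl on an aromatic carbon and keeps everything else in compound 3 unchanged.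

For the measured compounds named here, the only measured step is a 6.2-fold lower number from compound 1 to compound 3 (0.79 log units; beyond the scatter) for methyl in place of hydrogen on a nitrogen, a modest step beyond the scatter. Going by the values given here, compound 3 and compound 4 both keep that methyl, so this step bears only indirectly on the exchange, and no measured step covers the group that changes.

With so little to go on, a modest step towards a higher number is expected in this assay from the starting value of compound 3 at 130 nM and no more than that.

The estimated change is a 2.0-fold higher number from compound 3 to compound 4 (0.30 log units; within the scatter) in this direction.

Compound 4 is expected at 260 nM with 80 nM to 850 nM as the estimated range.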

Compound 4, half-maximal inhibitory concentration: 350 nM
Beside the measured number, compound 4's estimate is 1.3-fold (0.13 log units) below it, and the stated range covers the measured number.
By their numbers in this assay, from the lowest: compound 3; then compound 4; then compounds 1 and 2 (each within the scatter of the next).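

In this assay, for the compounds shown here, the change at the aromatic carbon ortho to the ethoxycarbonyl group, 5-methylthiophen-2-yl in place of 1-benzothiophen-2-yl, gives a 2.7-fold higher number from compound 3 to compound 4 (0.43 log units; beyond the scatter) as the only measured step at this position. The number therefore responds to the group held here, but the step is modest even though the six-membered aromatic ring of carbon only is lost and a methyl enters. The data shown offer no measured explanation for this step.

This single exchange does not separate the loss of the six-membered ring from the entry of the methyl. Also open, from the compounds shown here alone, are how a plain phenyl ring, a cyclohexyl ring or an aminomethyl group would behave at this position, and whether the methyl on the nitrogen gives a similar step alongside 5-methylthiophen-2-yl.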